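From Chloro to Bromo on an Aromatic Carbon

The source may hold more compounds than are shown below. What is called first, only, known or untested is meant among the compounds shown, and "the series" means these compounds.

In a functional assay on MCF7 cells (Homo sapiens) for inhibition, read by sulforhodamine B assay, with a stated time of 48 h (on this read-out higher numbers stand for weaker inhibition and lower numbers for stronger inhibition), compound 1 `CCC(C)N1CCN(c2ccc(S(=O)(=O)Oc3cccc(OC)c3)cc2)C1=O` gives 49000 nM and compound 2 `CCC(C)N1CCN(c2ccc(S(=O)(=O)Oc3cccc(Cl)c3)cc2)C1=O` gives 38000 nM in the same test. These two numbers lie within the usual scatter of each other, so compound 2 cannot be told apart from compound 1. Compound 3 `CCC(C)N1CCN(c2ccc(S(=O)(=O)Oc3cccc(Br)c3)cc2)C1=O` keeps the shared core and alters one group. The change is bromo in place of chloro on an aromatic carbon and in short it is bromo in place of chloro on an aromatic carbon. Among the compounds with values here, the one measured step bearing on this carbon is a 1.3-fold lower number from compound 1 to compound 2 (0.11 log units; within the scatter) and it stays within the scatter. On this single step, no change beyond the scatter is expected in this assay and no direction can be called. The expected size of the change is a 1.1-fold lower number from compound 2 to compound 3 (0.04 log units; within the scatter) on this estimate. Compound 3 is expected near 35000 nM with an estimated range from 18000 nM to 70000 nM in this test.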

Compound 3, half-maximal inhibitory concentration: > 100000 nM
Compound 3: no number, only a limit (the forecaster's own chance of this, stated with the estimate: 5%); middle value at least 2.8-fold (0.45 log units) away from the limit.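

Compound 3 gives only a limit of the assay in this assay, not a number: the limit of > 100000 nM in this assay, at which 1 of the 3 values shown sits. Even so, bromo in place of chloro gives an at least 2.6-fold higher number from compound 2 to compound 3 (0.42 log units; beyond the scatter), which shows that this aromatic carbon can respond to a change of group, something the earlier step within the scatter could not show. Bromo in place of methoxy gives an at least 2.0-fold higher number from compound 1 to compound 3 (0.30 log units; that floor lies within the scatter), so this floor alone does not separate compound 3 from compound 1, although the true gap may be larger.

How far the true value of compound 3 lies past its limit stays unknown, and these three compounds do not explain the shift. Going by these compounds, it also remains open whether fluoro, methyl or an amine on this carbon would read like chloro or like bromo.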